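The source may hold more compounds than are shown below. What is called first, only, known or untested is meant among the compounds shown, and "the series" means these compounds.

Measured compounds:
Compound 1 `CN(C)CCn1c(N)c(-c2nc3ccccc3[nH]2)c2nc(C#N)c(C#N)nc21`: 3780 nM
Compound 2 `CCN(CC)CCn1c(N)c(-c2nc3ccccc3[nH]2)c2nc(C#N)c(C#N)nc21`: 7150 nM
Compound 3 `CN(C)CCCCn1c(N)c(-c2nc3ccccc3o2)c2nc(C#N)c(C#N)nc21`: 960 nM

In a functional assay on HL60/MX2 cells (Homo sapiens) for antiproliferative activity, read by MTT assay, with a stated time of 48 h (on this read-out higher numbers stand for weaker inhibition and lower numbers for stronger inhibition), compound 1 gives 3780 nM and compound 2 gives 7150 nM. The two differ by one change, (diethylamino in place of dimethylamino on a saturated chain carbon, two bonds along the chain from an aromatic nitrogen), and that change made a step of a 1.9-fold higher number from compound 1 to compound 2 (0.28 log units; within the scatter). Compound 3, which gives 960 nM in this assay, has the lowest number of the three; the difference between its core and that of compound 1 is not broken down here. Compound 4 `CCN(CC)CCCCn1c(N)c(-c2nc3ccccc3o2)c2nc(C#N)c(C#N)nc21` has not yet been measured in this assay. It differs from compound 3 by diethylamino in place of dimethylamino on a saturated chain carbon, four bonds along the chain from an aromatic nitrogen. Going by the values given here, this is the same kind of change as the one from compound 1 to compound 2, though the place is not identical: there the group sat two bonds along the chain from an aromatic nitrogen, here it sits four bonds along. For compound 4 the expected step is a 1.6-fold higher number from compound 3 to compound 4 (0.19 log units; within the scatter), which rests on the earlier step of a 1.9-fold higher number from compound 1 to compound 2 (0.28 log units; within the scatter) being within the scatter. Compound 4 is therefore estimated at 1500 nM, with a likely range from 700 nM to 3500 nM.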

Compound 4, half-maximal inhibitory concentration: 1720 nM
The estimate for compound 4 lay 1.1-fold (0.06 log units) below the measured number; low and high end bracket the measured number.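

In this assay, diethylamino in place of dimethylamino gave a 1.8-fold higher number from compound 3 to compound 4 (0.25 log units; within the scatter), and this step matches the earlier one on the other core: the same change on two cores in this assay, a 1.9-fold higher number (0.28 log units; within the scatter) from compound 1 to compound 2 and a 1.8-fold higher number (0.25 log units; within the scatter) from compound 3 to compound 4, 1.1-fold (0.02 log units) apart, within the scatter of two such steps. Both steps lie within the scatter, so the two pairs agree that this change leaves the number within what repeated measurement would give, and they show no real effect of the swap on either core. Two pairs are a narrow base, and they do not show that the change would behave the same way on other cores or with other chains, although here it held with the group two bonds and four bonds along the chain from an aromatic nitrogen.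

The compounds shown leave open whether a bulkier amine, such as piperidine or morpholine, would move the number beyond the scatter. They also leave open how much of the gap between compound 1 and compound 3 belongs to the chain and how much to the core, since the core of compound 1 appears here only with the shorter chain.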